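The source may report more compounds than this note shows. Statements on the series, on what has been measured and on what is new or still open speak of the compounds shown alone.

Measured so far:
compound 1, `C=C1[C@@H](O)[C@H](n2cnc3c(Cl)nc(N)nc32)O[C@@H]1CO`, > 500000 nM
compound 2, `C=C1[C@@H](O)[C@H](n2cnc3c(N)nc(N)nc32)O[C@@H]1CO`, > 200000 nM
compound 3, `C=C1[C@H](n2cnc3c(Cl)nc(N)nc32)O[C@H](CO)[C@H]1O`, 176000 nM

In a functional assay on MT4 cells (Homo sapiens) for inhibition (a lower number here means a stronger inhibitor, a higher number a weaker inhibitor), compound 1 gives only a limit, > 500000 nM. Compound 2 likewise gives only a limit in this assay, > 200000 nM. Going by the values given here, compound 3 is the one compound with a read number in this assay, 176000 nM. The difference between the core of compound 1 and the core of compound 3 is not broken down here. The change amino in place of chloro on an aromatic carbon gives a step that the two limits leave unreadable from compound 1 to compound 2, so its size is not readable from that pair. Compound 4, `C=C1[C@H](n2cnc3c(N)nc(N)nc32)O[C@H](CO)[C@H]1O`, carries the same kind of change on the core of compound 3, (amino in place of chloro on an aromatic carbon). Among the compounds with values here, since the one measured step of this change is unreadable, the expectation for compound 4 rests only on compound 3 at 176000 nM and is taken as roughly flat, an estimated step of a 1.4-fold higher number from compound 3 to compound 4 (0.15 log units; within the scatter). Compound 4 is thus expected near 250000 nM in this assay, between 80000 nM and 1000000 nM, with a real chance that only a limit is reported.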

Compound 4, half-maximal inhibitory concentration: > 500000 nM
Compound 4 gave a limit, no number; the forecaster's own chance of this, stated with the estimate: 50%; middle value at least 2.0-fold (0.30 log units) away from the limit.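

In this assay, from the compounds shown here alone, amino in place of chloro on an aromatic carbon gives an at least 2.8-fold higher number from compound 3 to compound 4 (0.45 log units; beyond the scatter), so on this core the change weakens inhibition, and the true size of the step stays open since compound 4 gave only a limit. The same change on the core of compound 1 cannot be read, since compound 1 and compound 2 both gave only limits, so the series does not show whether the change carries from one core to the other. Compound 3 alone has a read number, and limits recur across the series: the limit of > 500000 nM in this assay, at which 2 of the 4 values shown sit.

Going by these compounds, how a methoxy or a methylamino group on that aromatic carbon would read on either core remains open. Also open, on these data alone, is whether any such group would give a read number in this assay on the core of compound 1.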